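Pyrrolidinylmethyl to dimethylcarbamoyl on the shared core

A few compounds are considered here, and "the series" means these few. Any claim that something is new, unique, unknown or untested is made for them only; others in the source may bear on it.

Compound 1 `CC(C)=CCC[C@]1(C)/C=C/[C@@H](OC(=O)C=C(C)C)[C@](C)(O)/C=C/C(=O)/C(CN2CCCC2)=C\C1` carries a (pyrrolidin-1-yl)methyl group on a double-bonded carbon of the ring of its core. Among the compounds with values here, in a functional assay on MCF7 cells (Homo sapiens) for antiproliferative activity, read by MTT assay, with a stated time of 48 h (on this read-out higher numbers stand for weaker inhibition and lower numbers for stronger inhibition), compound 1 gives 220 nM, the lowest of the two numbers measured so far. Compound 2 `CC(C)=CCC[C@]1(C)/C=C/[C@@H](OC(=O)C=C(C)C)[C@](C)(O)/C=C/C(=O)/C(COC(=O)c2ccc([N+](=O)[O-])cc2)=C\C1`, with ((4-nitrophenyl)carbonyl)oxy in place of pyrrolidin-1-yl on the saturated chain carbon, gives 670 nM in this assay; the step is a 3.0-fold higher number from compound 1 to compound 2 (0.48 log units; beyond the scatter).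

Compound 3 `CC(C)=CCC[C@]1(C)/C=C/[C@@H](OC(=O)C=C(C)C)[C@](C)(O)/C=C/C(=O)/C(C(=O)N(C)C)=C\C1` is the next member to be assessed. Its difference from compound 1 is dimethylcarbamoyl in place of (pyrrolidin-1-yl)methyl on a double-bonded ring carbon. The whole (pyrrolidin-1-yl)methyl arm is removed and a shorter, ring-free dimethylcarbamoyl is attached directly to the double-bonded ring carbon.

Within the data shown here, only the step from compound 1 to compound 2 bears on this, and it is modest though beyond the scatter. The present change also removes the pyrrolidine, so a step of similar size in the same direction, toward weaker inhibition, is expected as a 2.3-fold higher number from compound 1 to compound 3 (0.36 log units; beyond the scatter). For compound 3 in this assay the estimate is 500 nM, within a range from 180 nM to 1500 nM.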

Compound 3, half-maximal inhibitory concentration: 3670 nM
Estimate against measurement, compound 3: 7.3-fold (0.87 log units) below; measured number above the stated range.
By their numbers in this assay, from the lowest: compound 1; then compound 2; then compound 3.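

In this assay, dimethylcarbamoyl in place of (pyrrolidin-1-yl)methyl gives a 17-fold higher number from compound 1 to compound 3 (1.22 log units; beyond the scatter), a large step that far exceeds the modest 3.0-fold higher number from compound 1 to compound 2 (0.48 log units; beyond the scatter). Both steps remove the pyrrolidine, so its loss alone does not fix the size of the step at this double-bonded ring carbon; what replaces the (pyrrolidin-1-yl)methyl group matters a great deal here. Compound 3 is also the only one of the three with a carbonyl attached directly to the double-bonded ring carbon rather than a saturated chain carbon, but nothing available gives a reason for the large loss.

The three compounds leave the carbonyl attachment and the loss of the ring tangled together in a single change. On these data alone, a dimethylaminomethyl group, which keeps the saturated chain carbon and an amine without the ring, and a pyrrolidin-1-ylcarbonyl group, which keeps the ring on a carbonyl, would pull these two apart, and whether either stays near compound 1 at 220 nM remains open.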